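Hydroxy for methyl on the ketone-bearing aromatic ring

The compounds below may be only part of what the source reports. "The series", "measured", "known", "first", "only" and "open" are said of these compounds alone.

Compound 2 `Cc1c(OCCCCOc2ccc(F)c(C(=O)O)c2)ccc(C(=O)CC2CCCC2)c1C` gives "not determined" (no result reported) in an assay on HEK293 cells for positive allosteric modulation of metabotropic glutamate receptor 2 (Rattus norvegicus), read by thallium flux, with a stated time of 2.5 min (on this read-out higher numbers stand for an effect only at larger amounts of compound and lower numbers for an effect already at smaller amounts), so its place among the measured compounds cannot be fixed. Compound 1 `Cc1c(OCCCCOc2ccc(F)c(C(=O)O)c2)ccc(C(=O)CC(C)(C)C)c1O` gives 208 nM in this assay. Compound 3 `Cc1c(OCCCCOc2ccc(C(=O)O)c(Cl)c2)ccc(C(=O)CC2CCCC2)c1C` gives 2420 nM in this assay. The change from compound 2 to compound 4 `Cc1c(OCCCCOc2ccc(F)c(C(=O)O)c2)ccc(C(=O)CC2CCCC2)c1O` is hydroxy in place of methyl on an aromatic carbon. Among the measured compounds shown here, no measured pair of this kind exists, so the size of the step in this assay cannot be read off; a modest shift, not clearly beyond the scatter, is expected in either direction. The nearest guide is compound 1, at 208 nM, which shares the hydroxy group and differs only at the carbonyl-bearing side chain. Compound 4 is therefore expected to give about 300 nM in this assay, with a range from 100 nM to 900 nM.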

Compound 4, half-maximal effective concentration: 699 nM
Beside the measured number, compound 4's estimate is 2.3-fold (0.37 log units) below it, and the stated range covers the measured number.
By their numbers in this assay, from the lowest: compound 1; then compound 4; then compound 3.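

With the hydroxy group held constant, the side chain alone moves the number in this assay beyond the scatter: a 3.4-fold higher number from compound 1 to compound 4 (0.53 log units; beyond the scatter) with cyclopentyl in place of tert-butyl. Among the compounds shown here, compound 4 therefore sets the first readable value for a cyclopentyl side chain on the hydroxy-bearing core. No measurement on hand explains this step.

The hydroxy-for-methyl step itself cannot be read: compound 2 has no result. Also open, on these data alone, is how a methoxy group or an amine would compare with hydroxy on this aromatic carbon.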